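The source may report more compounds than this note shows. Statements on the series, on what has been measured and on what is new or still open speak of the compounds shown alone.

Measured so far in an assay on isolated protein for inhibition of protein deacetylase HDAC6 (Homo sapiens), read by fluorescence, with stated times of 10 min and 30 min, tested at 10 uM; a lower number here means less inhibition, a higher number more inhibition at the concentration tested (going by the name of the read-out):

compound 1 `CCOc1cc(NC(=O)CCCCCCC(=O)Nc2ccccc2N)cc2c1OCC([N+](=O)[O-])=C2` gives 52%
compound 2 `CCOc1cc(NC(=O)CCCCCCC(=O)Nc2cc(-c3ccc(C)s3)ccc2N)cc2c1OCC([N+](=O)[O-])=C2` gives 19%
compound 3 `CCOc1cc(NC(=O)CCCCC(=O)Nc2cc(-c3ccc(C)s3)ccc2N)cc2c1OCC([N+](=O)[O-])=C2` gives 8%

Compound 3 sits lowest of the three; its values against compound 2 and compound 1 both lie beyond the scatter. Within this set one change recurs. From compound 2 to compound 1 it is hydrogen in place of 5-methylthiophen-2-yl on an aromatic carbon, and it made a step of a number 33 percentage points higher from compound 2 to compound 1 (beyond the scatter). The same change, on the same place, takes compound 3 to compound 4 `CCOc1cc(NC(=O)CCCCC(=O)Nc2ccccc2N)cc2c1OCC([N+](=O)[O-])=C2`: hydrogen in place of 5-methylthiophen-2-yl on an aromatic carbon. How the core of compound 3 differs from the core of compound 2 is not broken down here. For compound 4 a step of about a number 30 percentage points higher from compound 3 to compound 4 (beyond the scatter) is expected, resting on the one measured occurrence, a number 33 percentage points higher from compound 2 to compound 1 (beyond the scatter), tempered by the lower starting point of compound 3. Compound 4 is therefore estimated at 38%, likely between 20% and 58%.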

Compound 4, a percentage reported as inhibition, at one concentration (the size of the read-out at that concentration, not a potency): 68%
For compound 4 the middle estimate is 30 percentage points below the measured one, outside the stated range (above it).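

Replacing 5-methylthiophen-2-yl with hydrogen gives a number 60 percentage points higher from compound 3 to compound 4 (beyond the scatter) in this assay, so the change raises inhibition on both cores shown. The direction carries from one core to the other, but the size of the step does not: the same change on two cores in this assay, a number 33 percentage points higher (beyond the scatter) from compound 2 to compound 1 and a number 60 percentage points higher (beyond the scatter) from compound 3 to compound 4, 27 percentage points apart, beyond the scatter of two such steps

For the compounds shown here, with only two cores, these results give no basis for predicting the step on a further core, and they do not explain why its size differs. Each figure is also a reading at one concentration, not a potency.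

Open, as far as these compounds go, is how a methyl or a phenyl on the same aromatic carbon would compare with hydrogen and 5-methylthiophen-2-yl. Also open, from the compounds shown here alone, is whether a longer chain would give a step of either size.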